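The compounds below may be only part of what the source reports. "The series", "measured", "known", "first", "only" and "open" are said of these compounds alone.

Measured so far in this series:
compound 1 `N#Cc1ncn(C/C=C2\OC(=O)C(OCc3ccccc3)=C2OCc2ccccc2)c1C#N`: 59000 nM
compound 2 `NC(=O)c1ncn(CCC2(O)NC(=O)C(OCc3ccccc3)=C2OCc2ccccc2)n1`: > 100000 nM

In a functional assay on HeLa cells (Homo sapiens) for antiproliferative activity, read by MTT assay, with a stated time of 72 h (on this read-out lower numbers stand for stronger inhibition and higher numbers for weaker inhibition), compound 1 gives 59000 nM, a number rather than a limit. For compound 2 the read-out is a limit only, > 100000 nM, and no number is known for it. Compound 2 sits at the limit of > 100000 nM in this assay, at which 1 of the 2 values shown sits, so its standing on the numbers shown is only that it lies at the top edge of what this assay reports. For the measured compounds named here, no single-point step connects compound 1 and compound 2; their two values show only that one returns a number and the other a limit.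

Compound 3 `NC(=O)c1ncn(CCC2(O)NC(=O)C(OCc3ccccc3)=C2OCc2ccccc2)c1C(N)=O` differs from compound 2 by 4,5-dicarbamoyl-1H-imidazol-1-yl in place of 3-carbamoyl-1H-1,2,4-triazol-1-yl on a saturated chain carbon, two bonds along the chain from a saturated ring carbon. Going by the values given here, no measured step is available to set the size of this change, and nothing among the measured values speaks for a move away from the limit. The step expected a number no higher from compound 2 to compound 3 (the limit leaves the size open) is therefore none beyond the scatter, with the outcome most likely another limit. Compound 3 is estimated at 100000 nM, within 30000 nM to 300000 nM.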

Compound 3, half-maximal inhibitory concentration: > 100000 nM
Compound 3 ended at the assay's limit; the forecaster's own chance of this, stated with the estimate: 70%; the middle value sits exactly at the limit.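

In this assay compound 2 and compound 3 both end at a limit, so no step can be read between them: the limit of > 100000 nM in this assay, at which 2 of the 3 values shown sit.

The compounds shown leave open whether 4,5-dicarbamoyl-1H-imidazol-1-yl in place of 3-carbamoyl-1H-1,2,4-triazol-1-yl changes the read-out at all, since neither compound has a number.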